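Adding a 4-iodophenyl to the amine of compound 3

The source may report more compounds than this note shows. Statements on the series, on what has been measured and on what is new or still open speak of the compounds shown alone.

Of the compounds shown here, three sharing one core have been tested in a functional assay on NCI-H1299 cells (Homo sapiens) for antiproliferative activity, read by MTT assay, with a stated time of 72 h; a higher number here means a weaker inhibitor, a lower number a stronger inhibitor. Compound 1 `O=C(C1=C(O)C(=O)N(CCCn2ccnc2)C1c1ccc(Br)cc1)c1ccccc1` gives 20000 nM, compound 2 `CC(C)OC1=C(C(=O)c2ccccc2)C(c2ccc(Br)cc2)N(CCCn2ccnc2)C1=O` gives 18900 nM, and compound 3 `NC1=C(C(=O)c2ccccc2)C(c2ccc(Br)cc2)N(CCCn2ccnc2)C1=O` gives 169000 nM. Compound 3 is the weakest of the three: the step of an 8.5-fold higher number from compound 1 to compound 3 (0.93 log units; beyond the scatter) and the step of an 8.9-fold higher number from compound 2 to compound 3 (0.95 log units; beyond the scatter) both exceed the scatter, whereas the step of a 1.1-fold lower number from compound 1 to compound 2 (0.02 log units; within the scatter) does not.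

Compound 4 `O=C(C1=C(Nc2ccc(I)cc2)C(=O)N(CCCn2ccnc2)C1c1ccc(Br)cc1)c1ccccc1` differs from compound 3 by 4-iodophenyl in place of hydrogen on an amine nitrogen. Going by the values given here, no measured pair shows this change, so the only guidance is indirect. The step of a 1.1-fold lower number from compound 1 to compound 2 (0.02 log units; within the scatter) shows that adding a group onto the heteroatom at this position left the number essentially unchanged, while the steps to compound 3 show that the amine itself carries the weakness. On that basis the expectation for compound 4 is a number close to that of compound 3, perhaps somewhat lower, with wide uncertainty: the estimated step is a 2.8-fold lower number from compound 3 to compound 4 (0.45 log units; beyond the scatter). Compound 4 is therefore expected to give about 60000 nM, within a range of 10000 nM to 250000 nM in this assay.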

Compound 4, half-maximal inhibitory concentration: 19400 nM
Compound 4: middle estimate off by 3.1-fold (0.49 log units), on the high side; the measured number falls inside the stated range.
By their numbers in this assay, from the lowest: compounds 2, 4 and 1 (each within the scatter of the next); then compound 3.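

In this assay, the position does not reject nitrogen as such: 4-iodophenyl in place of hydrogen on the amine nitrogen gives a clear recovery (an 8.7-fold lower number from compound 3 to compound 4 (0.94 log units; beyond the scatter)), so the weakness of compound 3 belongs to the plain amino group. The recovery goes only as far as the oxygen-linked compounds, as (4-iodophenyl)amino cannot be told apart from isopropoxy (a 1.0-fold higher number from compound 2 to compound 4 (0.01 log units; within the scatter)) or from hydroxy (a 1.0-fold lower number from compound 1 to compound 4 (0.01 log units; within the scatter)). Among these four compounds, only amino stands apart, and the aromatic ring brings no gain over the simple hydroxy.

No supporting measurement accounts for the difference between amino and (4-iodophenyl)amino. From the compounds shown here alone, whether the iodine, the ring or simply any group on this nitrogen restores the number stays open, and an unsubstituted phenyl or a methyl on the amine nitrogen would help to separate these.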